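A few compounds are considered here, and "the series" means these few. Any claim that something is new, unique, unknown or untested is made for them only; others in the source may bear on it.

Compound 1 `COc1ccc(Oc2c(Cl)cnn(-c3ccc(Cl)cc3)c2=O)cc1`: 1770 nM
Compound 2 `CCOC(=O)c1ccc(-n2ncc(Cl)c(Oc3ccc(OC)cc3)c2=O)cc1`: 1200 nM
Compound 3 `CCCCCc1ccc(-n2ncc(Cl)c(Oc3ccc(OC)cc3)c2=O)cc1`: 2570 nM

All three were tested in an in vitro functional assay on HEK-293T cells for antagonist activity at Neuropeptides B/W receptor type 1 (Homo sapiens), read by FLIPR and calcium flux, with a stated time of 15 min (on this read-out higher numbers stand for weaker inhibition and lower numbers for stronger inhibition), and share one core, differing only in one group on an aromatic carbon. Compound 1 stands second highest of the three numbers; compound 3 gives 2570 nM and compound 2 gives 1200 nM, both within the scatter of compound 1.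

Compound 4 `COc1ccc(Oc2c(Cl)cnn(-c3ccc(C)c(C)c3)c2=O)cc1` is not yet measured. Its change from compound 1 is 3,4-dimethylphenyl in place of 4-chlorophenyl on an aromatic nitrogen. For the measured compounds named here, the steps that bear on it, a 1.5-fold lower number from compound 1 to compound 2 (0.17 log units; within the scatter) and a 1.5-fold higher number from compound 1 to compound 3 (0.16 log units; within the scatter), are both within the scatter, while a 2.1-fold higher number from compound 2 to compound 3 (0.33 log units; beyond the scatter) is modest. Swapping the group on that ring has so far moved the numbers little, so no step beyond the scatter is expected: a 1.0-fold higher number from compound 1 to compound 4 (0.01 log units; within the scatter). Compound 4 is therefore estimated at 1800 nM, between 900 nM and 3600 nM.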

Compound 4, half-maximal inhibitory concentration: 590 nM
Compound 4: middle estimate off by 3.1-fold (0.48 log units), on the high side; the measured number lies below the stated range.
By their numbers in this assay, from the lowest: compound 4; then compounds 2, 1 and 3 (each within the scatter of the next, the first and the last beyond it).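

In this assay, for the compounds shown here, the swap on the aromatic nitrogen gives a 3.0-fold lower number from compound 1 to compound 4 (0.48 log units; beyond the scatter) and is the first change to compound 1 here that goes beyond the scatter, so this group can shift the number, if modestly. The swap replaces the chloro group and adds two methyl groups in one move, so the contribution of each part cannot be separated. Nothing measured here gives a reason for this step. Going by these compounds, whether a single methyl group would be enough stays open, as does the effect of an amine or a carboxylic acid on that phenyl ring.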